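The source may hold more compounds than are shown below. What is called first, only, known or untested is meant among the compounds shown, and "the series" means these compounds.

Measured so far in an ADME assay for protein binding, using equilibrium dialysis, at pH 7.4, tested at 2 uM; a higher number here means a larger unbound share of the compound, a lower number a smaller unbound share:
compound 1 `CC1CC=C(C(=O)N(c2cc(C#CC(C)(C)C)sc2C(=O)O)C(C)C)CC1` gives 0.08
compound 2 `CC(C)N(C(=O)[C@H]1CC[C@@H]2C[C@@H]2CC1)c1cc(C#CC(C)(C)C)sc1C(=O)O` gives 0.08
compound 3 `CC(C)N(C(=O)C1CCCCCC1)c1cc(C#CC(C)(C)C)sc1C(=O)O` gives 0.11

Compound 3 holds the highest of the three numbers, but its separation from the others is small: a 1.4-fold higher number from compound 1 to compound 3 (0.14 log units; within the scatter) and a 1.4-fold higher number from compound 2 to compound 3 (0.14 log units; within the scatter) both sit within the scatter, as does no change at the digits printed from compound 1 to compound 2 (within the scatter). The next compound is compound 4 `CC(C)N(c1cc(C#CC(C)(C)C)sc1C(=O)O)C(=O)[C@H]1CC[C@H](CF)CC1`. Its change from compound 3 is 4-(fluoromethyl)cyclohexyl in place of cycloheptyl on a carbonyl carbon. Each measured step likewise exchanged one ring of carbon only for another on the same carbonyl carbon, and none of them moved this assay beyond the scatter, so a step of that kind is expected again: a 1.1-fold higher number from compound 3 to compound 4 (0.04 log units; within the scatter). Compound 4 is therefore estimated at 0.12, with a range from 0.06 to 0.24.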

Compound 4, unbound fraction: 0.18
Compound 4: middle estimate off by 1.5-fold (0.18 log units), on the low side; the range from low to high includes it.
By their numbers in this assay, from the lowest: compounds 1, 2, 3 and 4 (each within the scatter of the next, the first and the last beyond it).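

In this assay, among these compounds, a change of ring on the carbonyl carbon moves the number beyond the scatter for the first time: 4-(fluoromethyl)cyclohexyl gives a 2.3-fold higher number from compound 1 to compound 4 (0.35 log units; beyond the scatter) and a 2.3-fold higher number from compound 2 to compound 4 (0.35 log units; beyond the scatter). Against cycloheptyl the same group gives only a 1.6-fold higher number from compound 3 to compound 4 (0.21 log units; within the scatter), so the gain is seen against two of the three earlier rings. Nothing available explains this difference.

Whether the fluorine matters stays open, since the compounds shown include no saturated 4-methylcyclohexyl for comparison. As far as these compounds go, how a hydroxymethyl or an aminomethyl group on that ring would read in this assay also remains open.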